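The source may report more compounds than this note shows. Statements on the series, on what has been measured and on what is new or still open speak of the compounds shown alone.

Measured so far:
compound 1, `CCN(CC)S(=O)(=O)c1ccc(S(=O)(=O)N2CCC[C@@H](C(=O)NC3CCOCC3)C2)cc1` — 8570 nM
compound 2, `CCN(CC)S(=O)(=O)c1ccc(S(=O)(=O)N2CCC[C@@H](C(=O)N3CCC(COC)CC3)C2)cc1` — 1360 nM
compound 3, `CCN(CC)S(=O)(=O)c1ccc(S(=O)(=O)N2CCC[C@@H](C(=O)N3CCC(F)(F)CC3)C2)cc1` — 120 nM

All three share one core and differ only in the group attached to the carbonyl carbon. In a functional assay on BXPC-3 cells (Homo sapiens) for inhibition, read by MTT assay, with a stated time of 7 days (on this read-out lower numbers stand for stronger inhibition and higher numbers for weaker inhibition), compound 3 gives the lowest number of the three: an 11-fold lower number from compound 2 to compound 3 (1.05 log units; beyond the scatter) and a 71-fold lower number from compound 1 to compound 3 (1.85 log units; beyond the scatter), both beyond the usual scatter. Compound 4, `CCN(CC)S(=O)(=O)c1ccc(S(=O)(=O)N2CCC[C@@H](C(=O)N3CCS(=O)(=O)CC3)C2)cc1`, keeps that core and changes the same group: 1,1-dioxothiomorpholin-4-yl in place of 4,4-difluoropiperidin-1-yl on a carbonyl carbon. The entering ring brings two hydrogen-bond acceptors where the leaving ring had none. Within the data shown here, the step that bears most on this is the one from compound 2, whose ring also carries an oxygen, to compound 3: an 11-fold lower number from compound 2 to compound 3 (1.05 log units; beyond the scatter). Compound 1, with an oxygen-bearing ring and an amide hydrogen, sits further still: a 71-fold lower number from compound 1 to compound 3 (1.85 log units; beyond the scatter). On those two steps a return to a weaker inhibition is expected, and compound 4 is estimated at 1500 nM, between 400 nM and 5500 nM, which means an expected step of a 13-fold higher number from compound 3 to compound 4 (1.10 log units; beyond the scatter).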

Compound 4, half-maximal inhibitory concentration: 4430 nM
Compound 4: middle estimate off by 3.0-fold (0.47 log units), on the low side; the measured number falls inside the stated range.
By their numbers in this assay, from the lowest: compound 3; then compound 2; then compounds 4 and 1 (each within the scatter of the next).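

In this assay, the step of a 37-fold higher number from compound 3 to compound 4 (1.57 log units; beyond the scatter) shows that this place on the carbonyl carbon tells apart two six-membered non-aromatic rings, so ring size alone does not hold the low number of compound 3. The 1,1-dioxothiomorpholin-4-yl ring also stands apart from the 4-(methoxymethyl)piperidin-1-yl ring (a 3.3-fold higher number from compound 2 to compound 4 (0.51 log units; beyond the scatter)), while the step of a 1.9-fold lower number from compound 1 to compound 4 (0.29 log units; within the scatter) shows that compound 4 reaches the range of compound 1 without an amide hydrogen. No measurement here explains the size of these steps.

From the compounds shown here alone, whether morpholin-4-yl, with a ring oxygen, or piperazin-1-yl, with a second ring nitrogen, would read closer to compound 3 or compound 4 stays open. So does whether plain piperidin-1-yl, without the two fluorines, would keep the number of compound 3.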